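Moving the hydroxyl one carbon along the chain

The compounds below may be only part of what the source reports. "The series", "measured", "known", "first", "only" and "open" are said of these compounds alone.

Three compounds share one core. Compound 1 `CCn1cnc2ncnc(N)c21` shows in an assay on CHO cells for displacement of a labelled ligand from adenosine receptor A1 (Homo sapiens) (a higher number here means a weaker inhibitor, a lower number a stronger inhibitor), only the limit > 100000 nM. Compound 2 `CCC(C)n1cnc2ncnc(N)c21` likewise reaches only the limit > 100000 nM in this assay. Compound 3 `Nc1ncnc2ncn(CCCO)c12` also stands at a limit in this assay, > 100000 nM. Hence the steps a step that the two limits leave unreadable from compound 1 to compound 2, a step that the two limits leave unreadable from compound 1 to compound 3 and a step that the two limits leave unreadable from compound 2 to compound 3 cannot be read, as the limit of > 100000 nM in this assay, at which 3 of the 3 values shown sit, states. Compound 4 `CC(O)Cn1cnc2ncnc(N)c21` differs from compound 3 by 1-hydroxyethyl in place of 2-hydroxyethyl on a saturated chain carbon bound to an aromatic nitrogen. No measured step bears on this rearrangement, and with every shown value sitting at the limit, compound 4 is expected to give 150000 nM in this assay, within 40000 nM to 600000 nM, an expected step that the limit leaves unreadable from compound 3 to compound 4 that most likely stays at the limit.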

Compound 4, inhibition constant: > 100000 nM
Compound 4: no number, only a limit; the forecaster's own chance of this, stated with the estimate: 85%; the middle value is on the limit's open side.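

Compound 4 also stands only at a limit in this assay, so its steps to compound 1, compound 2 and compound 3 cannot be read: the limit of > 100000 nM in this assay, at which 4 of the 4 values shown sit.

The compounds shown leave open whether any group on the aromatic nitrogen of the shared core gives a measurable value in this assay.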